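Replacing the formyl group of compound 3

The compounds below may be only part of what the source reports. "The series", "measured", "known", "first", "only" and "open" are said of these compounds alone.

In a functional assay on SEM cells (Homo sapiens) for cytotoxicity, with a stated time of 72 h (on this read-out lower numbers stand for an effect already at smaller amounts and higher numbers for an effect only at larger amounts of compound), compound 1 (`C=C[C@@](C)(/C=C/c1ccc(OC)cc1)CCC=C(C)C`) gives > 36600 nM as a limit of the assay, not a number. Compound 2 (`C=C[C@@](C)(/C=C/c1ccc(O)c(/C=C/C(N)=O)c1)CCC=C(C)C`) gives > 36600 nM in this assay, again a limit and not a number. Among the measured compounds shown here, compound 3 (`COc1ccc(/C=C/[C@@](C)(/C=C/c2ccc(O)c(C=O)c2)CCC=C(C)C)cc1`) gives 4550 nM in this assay and is the only compound with a number so far.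

Compound 4 (`COc1ccc(/C=C/[C@@](C)(/C=C/c2ccc(O)c(/C=C/C(=O)c3ccccc3)c2)CCC=C(C)C)cc1`) follows from compound 3 by one exchange, 2-benzoylethenyl in place of formyl on an aromatic carbon, ortho to a hydroxy group and meta to a large group (2-benzoylethenyl in place of formyl on an aromatic carbon). For the measured compounds named here, no measured pair differs in one place, so no measured step gives the size of this exchange. Going by the values given here, the only numerical anchor is compound 3 at 4550 nM, and the expectation stays close to it, with no shift beyond the usual scatter and a slight lean toward lower numbers. The estimated step of a 1.3-fold lower number from compound 3 to compound 4 (0.11 log units; within the scatter) is therefore small. For compound 4 the estimated value is 3500 nM, with an expected range from 1000 nM to 15000 nM in this assay, and a reading that reports only a limit remains possible.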

Compound 4, half-maximal effective concentration: 36600 nM
Compound 4: middle estimate off by 10-fold (1.02 log units), on the low side, outside the stated range (above it).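

Among the compounds shown here, exchanging formyl for 2-benzoylethenyl on an aromatic carbon, ortho to a hydroxy group and meta to a large group, gives an 8.0-fold higher number from compound 3 to compound 4 (0.91 log units; beyond the scatter) in this assay, so the read-out at this position responds to the exchange, which the earlier compounds could not show without a measured step. The two groups have equal counts of hydrogen-bond donors and acceptors but differ in heavy atoms, in the added six-membered aromatic ring and in the added double bond outside aromatic rings, and this single pair cannot separate these differences. The number for compound 4 coincides with the figure of the limit reached elsewhere in the series: the limit of > 36600 nM in this assay, at which 2 of the 4 values shown sit.

Going by these compounds, whether a small group such as an amine or a carboxylic acid in place of formyl would give a lower or a higher number than compound 3 remains open. Compound 1 and compound 2 each differ from compound 3 in more than one place, so the contribution of formyl itself to the reading of compound 3 also remains unresolved.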